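This account rests on a few compounds, and the source may have more. Where it says the series, first, only, none or still open, it means among the compounds named here.

Working notes on the series. In a toxicity assay on NIH3T3 cells (Mus musculus) for cytotoxicity, read by resazurin assay (a lower number here means that less compound is needed, a higher number that more compound is needed for the effect), compound 1 `c1ccc(-c2ccc(Cn3cncc3CNc3ccc(-c4onc5ccccc45)c(-c4ccccc4)c3)cc2)cc1` gives only a limit, > 10000 nM. Compound 2 `c1ccc(-c2ccc(Cn3cncc3CNc3ccc(-c4nc5ccccc5o4)c(-c4ccccc4)c3)cc2)cc1` likewise sits at a limit in this assay, > 10000 nM. Compound 3 `c1ccc(-c2ccc(Cn3cncc3CNc3ccc(-c4cncs4)c(-c4ccccc4)c3)cc2)cc1` also reaches only a limit in this assay, > 1000 nM. None of the three values is a number, so compound 3 stands at a limit and nowhere more exact. The steps a step that the two limits leave unreadable from compound 1 to compound 2, a step that the two limits leave unreadable from compound 1 to compound 3 and a step that the two limits leave unreadable from compound 2 to compound 3 cannot be read in size, as the limit of > 1000 nM in this assay, at which 1 of the 3 values shown sits, and the limit of > 10000 nM in this assay, at which 2 of the 3 values shown sit, record. Compound 4 `c1ccc(-c2ccc(Cn3cncc3CNc3ccc(N4CCCC4)c(-c4ccccc4)c3)cc2)cc1` differs from compound 3 by pyrrolidin-1-yl in place of 1,3-thiazol-5-yl on an aromatic carbon. For the measured compounds named here, no measured step bears readably on this change, so no shift beyond the scatter is expected. The step is expected as a step that the limit leaves unreadable from compound 3 to compound 4. Compound 4 is estimated at 15000 nM, within 3000 nM to 60000 nM, and most likely reported again only as a limit.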

Compound 4, half-maximal effective concentration: > 1000 nM
Compound 4 gave a limit, no number (the forecaster's own chance of this, stated with the estimate: 80%); the middle value does not contradict the limit.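

Compound 4 again gives only a limit in this assay, so its steps to compound 1, compound 2 and compound 3 cannot be read in size. The compounds shown leave open whether exchanging this group changes the read-out at all: none of the four gives a number.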